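This account rests on a few compounds, and the source may have more. Where it says the series, first, only, none or still open, it means among the compounds named here.

Compound 2 `CCc1cc(N)c2cc(NC(=O)/C=C/c3ccc(C(F)(F)F)cc3)ccc2n1` carries an ethyl group on the shared core, and in an assay on isolated protein for displacement of a labelled ligand from melanin-concentrating hormone receptor 1 (Homo sapiens) (on this read-out higher numbers stand for weaker inhibition and lower numbers for stronger inhibition), compound 2 gives 1.2 nM. Among the numbers measured so far it is matched only by compound 1 `Nc1cc(C2CCCC2)nc2ccc(NC(=O)/C=C/c3ccc(C(F)(F)F)cc3)cc12`, which in this assay gives 0.8 nM; the step of a 1.5-fold higher number from compound 1 to compound 2 (0.18 log units; within the scatter) lies within the scatter, so neither compound can be called the more potent. Compound 3 `Nc1cc(-c2ccccc2)nc2ccc(NC(=O)/C=C/c3ccc(C(F)(F)F)cc3)cc12` has not yet been measured. It differs from compound 2 in one place: phenyl in place of ethyl on an aromatic carbon. Going by the values given here, only the step of a 1.5-fold higher number from compound 1 to compound 2 (0.18 log units; within the scatter) bears on this change, since it concerns the same aromatic carbon, and it was small: exchanging cyclopentyl for ethyl left the number essentially where it was. A group larger than ethyl at this carbon is therefore known to be tolerated, and a phenyl is expected to behave in the same way, with no step beyond the scatter in this assay. Compound 3 is estimated at 1.5 nM, with a range from 0.5 nM to 5 nM. That estimate for compound 3 corresponds to an expected step of a 1.3-fold higher number from compound 2 to compound 3 (0.10 log units; within the scatter).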

Compound 3, half-maximal inhibitory concentration: 18.5 nM
Estimate against measurement, compound 3: 12-fold (1.09 log units) below; measured number above the stated range.
By their numbers in this assay, from the lowest: compounds 1 and 2 (each within the scatter of the next); then compound 3.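

In this assay the aromatic carbon next to the ring nitrogen proves sensitive to what it carries, with a 15-fold higher number from compound 2 to compound 3 (1.19 log units; beyond the scatter) when phenyl replaces ethyl and a 23-fold higher number from compound 1 to compound 3 (1.36 log units; beyond the scatter) when phenyl replaces cyclopentyl. Compound 3 is therefore the weakest of the three, and the position does not accept every ring: cyclopentyl stays within the scatter of ethyl, while phenyl, a six-membered aromatic ring of carbon only, does not. Nothing available explains this loss.

The compounds shown leave open whether the aromatic ring itself or its size sets the loss, a question that a cyclohexyl group would help to separate. Also open, going by these compounds, is how a pyridyl ring, a benzyl group or a small amine at this carbon would read.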